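Notes on aryl ketone replacements in one antiproliferative series

The source may report more compounds than this note shows. Statements on the series, on what has been measured and on what is new or still open speak of the compounds shown alone.

Measured so far:
compound 1 `COc1ccc(/C=C/c2cc(OC)cc(OC)c2/C=C/C(=O)c2ccc(Cl)c(Cl)c2)cc1` — in a functional assay on HepG2 cells (Homo sapiens) for antiproliferative activity, read by MTT assay, with a stated time of 48 h (on this read-out higher numbers stand for weaker inhibition and lower numbers for stronger inhibition), compound 1 gives 10.8 ug/mL
compound 2 `COc1ccc(/C=C/c2cc(OC)cc(OC)c2/C=C/C(=O)c2ccc(C)cc2)cc1` — in this assay compound 2 gives 4.8 ug/mL
compound 3 `COc1ccc(/C=C/c2cc(OC)cc(OC)c2/C=C/C(=O)c2ccc(N)cc2)cc1` — in this assay compound 3 gives 7.5 ug/mL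

Compound 1 carries the highest number of the three in this assay; its nearest neighbour is compound 3 and its furthest is compound 2. The steps away from compound 1 both run downward: a 2.3-fold lower number from compound 1 to compound 2 (0.35 log units; beyond the scatter), and a 1.4-fold lower number from compound 1 to compound 3 (0.16 log units; within the scatter). Between compounds 2 and 3 the step is a 1.6-fold higher number from compound 2 to compound 3 (0.19 log units; within the scatter).

Compound 4 `COc1ccc(/C=C/c2cc(OC)cc(OC)c2/C=C/C(=O)c2ccc(F)cc2)cc1` is not yet measured. Relative to compound 1 the change is 4-fluorophenyl in place of 3,4-dichlorophenyl on a carbonyl carbon. The two steps that bear on it, both exchanging the 3,4-dichlorophenyl on the carbonyl carbon for a singly substituted phenyl, were modest or within the scatter, and both lowered the number. For compound 4 a similar modest lowering is therefore expected, with a fair chance that it falls within the scatter of compound 1. The expected step is a 1.5-fold lower number from compound 1 to compound 4 (0.19 log units; within the scatter). Compound 4 is estimated at 7 ug/mL, in the range 3.5 ug/mL to 14 ug/mL.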

Compound 4, half-maximal inhibitory concentration: 12.2 ug/mL
The estimate for compound 4 lay 1.7-fold (0.24 log units) below the measured number; the range from low to high includes it.
By their numbers in this assay, from the lowest: compounds 2, 3, 1 and 4 (each within the scatter of the next, the first and the last beyond it).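

On a carbonyl carbon, 4-fluorophenyl in place of 3,4-dichlorophenyl leaves the read-out in this assay effectively unchanged (a 1.1-fold higher number from compound 1 to compound 4 (0.05 log units; within the scatter)), so this exchange does not lower the number as the two earlier exchanges of the 3,4-dichlorophenyl did. Fluoro in place of amino stays inside the scatter (a 1.6-fold higher number from compound 3 to compound 4 (0.21 log units; within the scatter)), while fluoro in place of methyl does not (a 2.5-fold higher number from compound 2 to compound 4 (0.41 log units; beyond the scatter)); compound 2 now stands apart from both halogen-bearing compounds, and compound 3 remains within the scatter of all three others. Nothing at hand speaks to a cause for this separation.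

Open, on these data alone, is whether the separation of compound 2 is particular to methyl or also holds for a 4-ethylphenyl or a 4-methoxyphenyl on the carbonyl carbon. Also open, as far as these compounds go, is whether a 4-chlorophenyl would read with compounds 1 and 4.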